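Pyrimidinylamino against chloropyridinyloxy on the shared core

This account rests on a few compounds, and the source may have more. Where it says the series, first, only, none or still open, it means among the compounds named here.

Compound 1 `Cc1cc(Oc2ccccc2Cl)c(S(C)(=O)=O)cc1C(=O)N=C(N)N` gives 14 nM in a functional assay for inhibition of sodium/hydrogen exchanger (Oryctolagus cuniculus); a lower number here means a stronger inhibitor, a higher number a weaker inhibitor. Among the compounds with values here, compound 2 `Cc1cc(Nc2ncccn2)c(S(C)(=O)=O)cc1C(=O)N=C(N)N` gives 8.3 nM in this assay, the lowest of the two numbers so far, and the step of a 1.7-fold lower number from compound 1 to compound 2 (0.23 log units; within the scatter) stays within the scatter. Compound 3 `Cc1cc(Oc2cncc(Cl)c2)c(S(C)(=O)=O)cc1C(=O)N=C(N)N` differs from compound 2 by (5-chloropyridin-3-yl)oxy in place of (pyrimidin-2-yl)amino on an aromatic carbon. Within the data shown here, the only step that bears on this change is a 1.7-fold lower number from compound 1 to compound 2 (0.23 log units; within the scatter), which swapped 2-chlorophenoxy for (pyrimidin-2-yl)amino without leaving the scatter; the present change largely reverses that swap, so no step beyond the scatter is expected in this assay. Compound 3 is therefore estimated at 12 nM, with a range of 5 nM to 30 nM. The expected step is a 1.4-fold higher number from compound 2 to compound 3 (0.16 log units; within the scatter).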

Compound 3, half-maximal inhibitory concentration: 14 nM
Compound 3: middle estimate off by 1.2-fold (0.07 log units), on the low side; the range from low to high includes it.
By their numbers in this assay, from the lowest: compounds 2, 1 and 3 (each within the scatter of the next).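

In this assay, the place ortho to the methylsulfonyl group accepts (5-chloropyridin-3-yl)oxy as well as (pyrimidin-2-yl)amino, with the two compounds inside the scatter (a 1.7-fold higher number from compound 2 to compound 3 (0.23 log units; within the scatter)). On the oxygen, 5-chloropyridin-3-yl in place of 2-chlorophenyl also leaves the read-out inside the scatter (no change at the digits printed from compound 1 to compound 3 (within the scatter)), so this assay does not separate these aromatic rings or the oxygen and amino links. Nothing available explains why these values lie so close. As far as these compounds go, it remains open whether a group without an aromatic ring, such as a small amine or a carboxylic acid, would stay within the scatter here.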